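Capping the aniline nitrogen: from compound 2 to compound 3

A few compounds are considered here, and "the series" means these few. Any claim that something is new, unique, unknown or untested is made for them only; others in the source may bear on it.

Compound 1 `CCOc1ccc(-c2ccc(N(C[C@@H](N)[C@@H](C)CC)C(=O)[C@@H]3C[C@H]3c3ccccc3)cc2)cc1` and compound 2 `CC[C@H](C)[C@H](N)CN(C(=O)[C@@H]1C[C@H]1c1ccccc1)c1ccc(-c2ccc(N)cc2)cc1` share one core and differ only in a single group on the outer aromatic ring. In a functional assay for agonist activity at G protein-coupled receptor 88 (Homo sapiens), read by HTRF and cAMP accumulation (on this read-out lower numbers stand for an effect already at smaller amounts and higher numbers for an effect only at larger amounts of compound), compound 1 gives 90 nM, while compound 2 gives 320 nM. The step of a 3.6-fold higher number from compound 1 to compound 2 (0.55 log units; beyond the scatter) corresponds to amino in place of ethoxy on an aromatic carbon. Among the two measured compounds, compound 2 thus stands with the higher number, and compound 1 is the only neighbour for comparison. Compound 3 `CC[C@H](C)[C@H](N)CN(C(=O)[C@@H]1C[C@H]1c1ccccc1)c1ccc(-c2ccc(NS(C)(=O)=O)cc2)cc1` takes the next step: methylsulfonyl in place of hydrogen on a nitrogen on an aromatic ring. Going by the values given here, no measured step covers this particular change, so the only guide is that swapping the group on this ring already moved the number. An expected step of a 1.9-fold higher number from compound 2 to compound 3 (0.27 log units; within the scatter) seems reasonable, cautiously toward a higher number. Compound 3 is therefore estimated at 600 nM, with a range from 150 nM to 2500 nM.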

Compound 3, half-maximal effective concentration: 1200 nM
The estimate for compound 3 lay 2.0-fold (0.30 log units) below the measured number, and the stated range covers the measured number.
By their numbers in this assay, from the lowest: compound 1; then compound 2; then compound 3.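

In this assay, placing methylsulfonyl on this nitrogen gives a 3.8-fold higher number from compound 2 to compound 3 (0.57 log units; beyond the scatter), so what the nitrogen carries matters, and capping it does not bring the number back towards that of the ethoxy compound. Set directly against ethoxy, methanesulfonamido gives a 13-fold higher number from compound 1 to compound 3 (1.12 log units; beyond the scatter), a large step, which shows that the three groups on this aromatic carbon spread widely and that ethoxy holds the lowest number among them. No measurement at hand gives a reason for this rise.

As far as these compounds go, it remains open whether an acetyl group on the same nitrogen would behave like methylsulfonyl, which would show whether the rise belongs to the sulfonyl group or to capping the nitrogen at all. From the compounds shown here alone, it is equally open whether a methoxy group or a longer alkoxy chain would give a number lower than that of compound 1.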